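The source may report more compounds than this note shows. Statements on the series, on what has been measured and on what is new or still open speak of the compounds shown alone.

Working notes on the series, measured so far in a functional assay on DU-145 cells (Homo sapiens) for antiproliferative activity, read by sulforhodamine B assay, with a stated time of 48 h; on this read-out lower numbers stand for stronger inhibition and higher numbers for weaker inhibition

compound 1 `O=C1NCCN1c1ccc(S(=O)(=O)Nc2ccc3[nH]ccc3c2)cc1` gives 1370 nM
compound 2 `COc1cc(NS(=O)(=O)c2ccc(N3CCNC3=O)cc2)cc(OC)c1OC` gives 51 nM
compound 3 `Cc1cc(C)cc(NS(=O)(=O)c2ccc(N3CCNC3=O)cc2)c1` gives 430 nM

Compound 3 at 430 nM holds the second highest of the three numbers, under compound 1 and over compound 2, and both gaps lie beyond the scatter. For the measured compounds named here, no two measured compounds differ in one place only, so no measured step bears directly on the next change.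

Compound 4 `COc1cccc(NS(=O)(=O)c2ccc(N3CCNC3=O)cc2)c1` differs from compound 3 in one place: 3-methoxyphenyl in place of 3,5-dimethylphenyl on a sulfonamide nitrogen.

Going by the values given here, the only guide is indirect. Among the compounds with values here, compound 2, the one measured member bearing methoxy groups, gives 51 nM in this assay and so gives the lowest of the three numbers. That single value leans the expectation toward lower numbers, but compound 2 differs from compound 4 in more than one respect, so only a small move is expected. The expected step is a 1.7-fold lower number from compound 3 to compound 4 (0.22 log units; within the scatter) and it is expected to stay within the scatter. For compound 4 the estimate is 260 nM as the middle value, with 90 nM to 750 nM as the expected range.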

Compound 4, half-maximal inhibitory concentration: 650 nM
Estimate against measurement, compound 4: 2.5-fold (0.40 log units) below, and the stated range covers the measured number.
By their numbers in this assay, from the lowest: compound 2; then compounds 3 and 4 (each within the scatter of the next); then compound 1.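

In this assay, for the compounds shown here, placing 3-methoxyphenyl where 3,5-dimethylphenyl stood on a sulfonamide nitrogen gives a 1.5-fold higher number from compound 3 to compound 4 (0.18 log units; within the scatter), the first step between compounds that differ in one place, and it shows that this exchange leaves the number within the scatter. The two groups match in heavy-atom count and in their six-membered aromatic ring of carbon only, while the entering group carries one hydrogen-bond acceptor and the leaving group none, so at this position, for this pair, that difference comes with no change that can be read beyond the scatter. No measurement beyond the antiproliferative numbers themselves is available to account for this result.

Going by these compounds alone, compound 1 and compound 2 are joined to compound 3 and compound 4 by no single-place step, so what separates their numbers from those of the other two cannot yet be assigned to any one structural feature. Also open, from the compounds shown here alone, is how this position responds to a group of a different kind on the sulfonamide nitrogen, such as a phenyl ring bearing an amine or a carboxylic acid, or a longer chain in place of the ring.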